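The source may report more compounds than this note shows. Statements on the series, on what has been measured and on what is new or still open speak of the compounds shown alone.

Working notes on the series, all read in a functional assay on MCF7 cells (Homo sapiens) for antiproliferative activity, read by CCK-8 assay, with a stated time of 72 h; a lower number here means a stronger inhibitor of growth, a higher number a weaker inhibitor of growth. Compound 1 `CCC1C(=O)N(C)c2cnc(-n3ccc4cc(C(=O)NC)ccc43)nc2N1c1ccn(C)n1` gives 35400 nM, compound 2 `CCCNC(=O)c1ccc2c(ccn2-c2ncc3c(n2)N(c2ccn(C)n2)C(CC)C(=O)N3C)c1` gives 6420 nM and compound 3 `CCC1C(=O)N(C)c2cnc(-n3ccc4cc(C(=O)NCC(C)C)ccc43)nc2N1c1ccn(C)n1` gives 4810 nM. Compound 3 therefore sits with compound 2 at the low end of these three numbers: a 1.3-fold lower number from compound 2 to compound 3 (0.13 log units; within the scatter) stays within the scatter, while a 7.4-fold lower number from compound 1 to compound 3 (0.87 log units; beyond the scatter) lies beyond it.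

The next compound is compound 4 `CCC1C(=O)N(C)c2cnc(-n3ccc4cc(C(=O)NC5CCCC5)ccc43)nc2N1c1ccn(C)n1`, which has cyclopentyl in place of isobutyl on an amide-type nitrogen. The closest evidence comes from changes to the same amide substituent. Extending it gave a 5.5-fold lower number from compound 1 to compound 2 (0.74 log units; beyond the scatter) and a 7.4-fold lower number from compound 1 to compound 3 (0.87 log units; beyond the scatter), but the further change, a 1.3-fold lower number from compound 2 to compound 3 (0.13 log units; within the scatter), produced no shift beyond the scatter. Going by the values given here, none of the measured compounds carries a ring at this place, so that feature remains untested. No step beyond the scatter is therefore expected, and the estimated change is a 1.2-fold lower number from compound 3 to compound 4 (0.08 log units; within the scatter). For compound 4 the expected value is 4000 nM, with an estimated range of 1800 nM to 9000 nM.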

Compound 4, concentration for 50% growth inhibition: "not active" (no number reported)
Nothing numeric was reported for compound 4, so the estimate cannot be set against anything.
By their numbers in this assay, from the lowest: compounds 3 and 2 (each within the scatter of the next); then compound 1.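

Going by these compounds alone, compound 4 is reported as not active in this assay with no number, so no step to it from compound 3 or any other compound can be read. Nothing available bears on this result. The compounds shown leave open how any ring on the amide-type nitrogen compares numerically with isobutyl.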